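Heteroaryl swap at the aminomethyl position: solubility notes

A few compounds are considered here, and "the series" means these few. Any claim that something is new, unique, unknown or untested is made for them only; others in the source may bear on it.

Compound 3 `Cc1cc(NCc2cnccn2)n2nc(C)c(-c3ccccc3)c2n1` gives 7100 nM in a physicochemical assay for solubility, read by HPLC, using the shake flask method, measured as kinetic solubility, with a stated time of 2 h, at pH 7.4 (on this read-out lower numbers stand for lower solubility and higher numbers for higher solubility), the lowest of the three measured numbers; compound 2 `Cc1cc(NCc2ncccn2)n2nc(C)c(-c3ccccc3)c2n1` gives 37900 nM and compound 1 `Cc1cc(NCc2ccncc2)n2nc(C)c(-c3ccccc3)c2n1` gives 134000 nM. Compound 4 `Cc1cc(NCc2nccs2)n2nc(C)c(-c3ccccc3)c2n1` is unmeasured and differs from compound 3 by 1,3-thiazol-2-yl in place of pyrazin-2-yl on a saturated chain carbon bound to a nitrogen on an aromatic ring. Within the data shown here, none of the measured steps covers a five-membered ring: all three exchange one six-membered heteroaryl for another, with a 3.5-fold lower number from compound 1 to compound 2 (0.55 log units; beyond the scatter), a 5.3-fold lower number from compound 2 to compound 3 (0.73 log units; beyond the scatter) and a 19-fold lower number from compound 1 to compound 3 (1.28 log units; beyond the scatter). Among the measured compounds shown here, they show only that such a swap on the shared core shifts this assay by modest to large amounts. For compound 4 a modest downward step is expected, with the direction far from certain, a 1.4-fold lower number from compound 3 to compound 4 (0.15 log units; within the scatter). Compound 4 is therefore estimated at 5000 nM, between 1500 nM and 20000 nM.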

Compound 4, solubility: 108000 nM
The estimate for compound 4 lay 22-fold (1.33 log units) below the measured number, outside the stated range (above it).
By their numbers in this assay, from the lowest: compound 3; then compound 2; then compounds 4 and 1 (each within the scatter of the next).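

The first five-membered ring at this position shows that the spread seen among the six-membered rings is not confined to them: 1,3-thiazol-2-yl gives a 15-fold higher number from compound 3 to compound 4 (1.18 log units; beyond the scatter) and a 2.8-fold higher number from compound 2 to compound 4 (0.45 log units; beyond the scatter). Against pyridin-4-yl it is not separated, with a 1.2-fold lower number from compound 1 to compound 4 (0.09 log units; within the scatter). No measurement shown accounts for the difference from pyrazin-2-yl.

The compounds shown do not separate ring size from the sulfur atom. Going by these compounds, whether 1,3-oxazol-2-yl, or a longer chain carrying 1,3-thiazol-2-yl, would follow compound 4 stays open.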